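A few compounds are considered here, and "the series" means these few. Any claim that something is new, unique, unknown or untested is made for them only; others in the source may bear on it.

Compound 1 `CCOc1ccccc1-c1nc2ccccc2[nH]1` was tested in a functional assay on the whole organism (ileum) with Rattus norvegicus as the target (a higher number here means a larger maximal response, a lower number a smaller maximal response), where compound 1 gives 50%. Going by the values given here, its one measured neighbour is compound 2 `c1ccc(COc2ccccc2-c2nc3ccccc3[nH]2)cc1`, which in this assay gives 51.4%; the step of a number 1.4 percentage points higher from compound 1 to compound 2 (within the scatter) shows that widening the group on the oxygen of the aromatic ring from methyl to phenyl on the saturated chain carbon left the largest response essentially unchanged. With only these two numbers in hand, compound 1 sits at a value that is indistinguishable from that of compound 2.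

The next compound, compound 3 `O=[N+]([O-])c1ccccc1-c1nc2ccccc2[nH]1`, differs from compound 1 in a single change: nitro in place of ethoxy on an aromatic carbon. Here the ethoxy leaves altogether and a nitro enters on the same aromatic carbon, so the only measured step, which kept the oxygen and enlarged the chain, bears on it but weakly. Among the compounds with values here, no measured pair shows what such an exchange does in this assay. The expectation for compound 3 is therefore anchored on the value of compound 1 and broad, with a step of no change at the digits printed from compound 1 to compound 3 (within the scatter) expected. Compound 3 is thus estimated at 50%, within the range 25% to 75%.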

Compound 3, largest response reached (Emax), in percent of the reference or control that the assay uses: 11.1%
Compound 3: the middle estimate sits 38.9 percentage points above what was measured; measured number outside the range, below it.
By their numbers in this assay, from the lowest: compound 3; then compounds 1 and 2 (each within the scatter of the next).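

At this aromatic carbon, ortho to a group of 9 heavy atoms, the exchange of ethoxy for nitro gives in this assay a number 38.9 percentage points lower from compound 1 to compound 3 (beyond the scatter) and so shows that the largest response depends on the group placed here, which the earlier step of a number 1.4 percentage points higher from compound 1 to compound 2 (within the scatter) could not show while the oxygen stayed on the ring. Ethoxy and nitro both count 3 heavy atoms, so this large step comes with no change in that count. Nothing measured here accounts for the step.

On these data alone, it remains open whether the step follows the loss of the ethoxy or the arrival of the nitro, a question that a plain hydrogen, an amine or a carboxylic acid on the same carbon would help to settle. As far as these compounds go, whether nitro on another carbon of that ring would give a similar step also remains open.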